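The source may hold more compounds than are shown below. What is called first, only, known or untested is meant among the compounds shown, and "the series" means these compounds.

In a functional assay on LNCaP cells (Homo sapiens) for cytotoxicity, read by MTT assay, with a stated time of 72 h (on this read-out lower numbers stand for stronger inhibition and higher numbers for weaker inhibition), compound 1 (`Nc1ccc(Nc2c(C(=O)NCc3ccc(F)cc3)nc(Br)c3cccnc23)cc1`) gives 7000 nM. For the measured compounds named here, this is the only number available so far, so it cannot yet be ranked against another compound. Compound 2 (`N[C@H]1CC[C@H](Nc2c(C(=O)NCc3ccc(F)cc3)nc(N3CCCCC3)c3cccnc23)CC1`) offers no comparison, as its entry reads "not determined" (no result reported). Compound 3 (`COC(=O)CNc1c(C(=O)NCc2ccc(F)cc2)nc(Br)c2cccnc12`) keeps the core of compound 1 and carries (methoxycarbonyl)methyl in place of 4-aminophenyl on a nitrogen on an aromatic ring. Going by the values given here, no measured pair covers this change, so the expectation rests on the single value of compound 1 and remains loose. A modest weakening in this assay is expected, although a result within the scatter would not be surprising. The estimated step is a 1.7-fold higher number from compound 1 to compound 3 (0.23 log units; within the scatter). For compound 3, the expected value is 12000 nM, with an estimated range of 3500 nM to 40000 nM.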

Compound 3, half-maximal inhibitory concentration: 5000 nM
Estimate against measurement, compound 3: 2.4-fold (0.38 log units) above, and the stated range covers the measured number.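

In this assay, for the compounds shown here, the exchange of 4-aminophenyl for (methoxycarbonyl)methyl on a nitrogen on an aromatic ring gives the first readable step: a 1.4-fold lower number from compound 1 to compound 3 (0.15 log units; within the scatter). At this position, the six-membered aromatic ring of carbon and the hydrogen-bond donor of the leaving group can therefore give way to a group without a ring and without a donor, with no change beyond the scatter. No measured finding available here accounts for this result.

From the compounds shown here alone, whether a carboxylic acid in place of the methyl ester, or a longer chain carrying the ester, would move the number in this assay beyond the scatter remains open. A single pair also leaves open whether this exchange would read the same with other groups elsewhere on the shared core.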